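A few compounds are considered here, and "the series" means these few. Any claim that something is new, unique, unknown or untested is made for them only; others in the source may bear on it.

In a functional assay on HOP-62 cells (Homo sapiens) for inhibition, read by sulforhodamine B assay (on this read-out lower numbers stand for stronger inhibition of growth and higher numbers for weaker inhibition of growth), compound 1 `FC(F)(F)c1ccc(-c2ccc(-c3ccc(-c4nc5ccccc5[nH]4)cc3)cc2)cc1` gives 100000 nM. Compound 2 `FC(F)(F)Oc1ccc(-c2ccc(-c3ccc(-c4nc5ccccc5[nH]4)cc3)cc2)cc1` gives 100000 nM, level with compound 1, and compound 3 `CN(C)c1ccc(-c2ccc(-c3ccc(-c4nc5ccccc5[nH]4)cc3)cc2)cc1` gives 100000 nM. Among the measured compounds shown here, compound 2 therefore stands with both of its measured neighbours, and exchanging trifluoromethyl, trifluoromethoxy and dimethylamino produced no measurable step: no change at the digits printed from compound 1 to compound 2 (within the scatter), no change at the digits printed from compound 1 to compound 3 (within the scatter) and no change at the digits printed from compound 2 to compound 3 (within the scatter).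

Compound 4 `Cc1ccc2[nH]c(-c3ccc(-c4ccc(-c5ccc(OC(F)(F)F)cc5)cc4)cc3)nc2c1` keeps the trifluoromethoxy group of compound 2 and differs elsewhere: methyl in place of hydrogen on an aromatic carbon. This is methyl in place of hydrogen on an aromatic carbon, taking 1H-benzimidazol-2-yl to 5-methyl-1H-benzimidazol-2-yl. For the measured compounds named here, none of the measured steps involves this change, so they offer only indirect guidance, and the data show no substitution that has yet moved this assay. No step beyond the scatter is therefore expected, although a shift towards stronger inhibition of growth cannot be excluded. The expected result is no change at the digits printed from compound 2 to compound 4 (within the scatter). Compound 4 is estimated at 100000 nM, with an expected range of 30000 nM to 100000 nM.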

Compound 4, concentration for 50% growth inhibition: 24200 nM
Estimate against measurement, compound 4: 4.1-fold (0.62 log units) above; measured number outside the range, below it.
By their numbers in this assay, from the lowest: compound 4; then compounds 1, 2 and 3 (each within the scatter of the next).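

Taking 1H-benzimidazol-2-yl to 5-methyl-1H-benzimidazol-2-yl gives a 4.1-fold lower number from compound 2 to compound 4 (0.62 log units; beyond the scatter) in this assay, a modest step and the only one shown that lies beyond the scatter. The exchanges among trifluoromethyl, trifluoromethoxy and dimethylamino had left the read-out level, whereas a single added methyl on an aromatic carbon of the fused two-ring system does register, so this position responds to substitution. Nothing available explains why this methyl shifts growth inhibition.

The compounds shown leave open whether a longer chain such as ethyl, or a methoxy group, chlorine or an amine at this position would move the number further, or whether a carboxylic acid there would reverse the step. They also leave open whether the same methyl has any effect when trifluoromethyl or dimethylamino replaces trifluoromethoxy.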